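A few compounds are considered here, and "the series" means these few. Any claim that something is new, unique, unknown or untested is made for them only; others in the source may bear on it.

Measured compounds
- compound 1 `CCOC(=O)C1=C(C)N/C(=C/c2cc(C)n(-c3ccc(N(C)C)cc3)c2C)C1=O`: 3.4
- compound 2 `CCOC(=O)C1=C(C)N/C(=C/c2cc(C)n(-c3ccc(SC)cc3)c2C)C1=O`: "not determined" (no result reported)

In a physicochemical assay for lipophilicity, read by HPLC, at pH 7.4 (on this read-out lower numbers stand for lower lipophilicity and higher numbers for higher lipophilicity), compound 1 gives 3.4. For compound 2 this assay reports "not determined" (no result reported), so no number stands for compound 2 and its place within the series cannot be fixed from the measurements; only the value of compound 1 is available as a point of reference.

Compound 3 `CCOC(=O)C1=C(C)N/C(=C/c2cc(C)n(-c3ccc(CN4CCCCC4)cc3)c2C)C1=O` is the next member and awaits measurement in this assay. It differs from compound 2 in one place: (piperidin-1-yl)methyl in place of methylsulfanyl on an aromatic carbon. Going by the values given here, no measured step covers a change of this kind, and no measured step between any two compounds is available at all. The step from compound 2 to compound 3 is expected to go downward in this assay, by an amount beyond the usual scatter, though with wide uncertainty.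

For compound 3 the estimated value in this assay is 2.6, with a range from 1.8 to 3.4.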

Compound 3, distribution coefficient: 8.5
Compound 3: the middle estimate sits 5.90 log units below what was measured; the measured number lies above the stated range.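

In this assay, (piperidin-1-yl)methyl in place of dimethylamino on an aromatic carbon, para to a large group, gives a number 5.10 log units higher from compound 1 to compound 3 (beyond the scatter), so the read-out at this position is far from indifferent to the group it carries. Compound 2 has no number, so the step from compound 2 to compound 3 cannot be read, and the exchange of methylsulfanyl remains without a measured size. Going by these compounds alone, nothing measured so far accounts for the size of the step from dimethylamino.

The compounds shown do not separate the ring from the added methylene, a question that (dimethylamino)methyl or piperidin-1-yl at this place would address. On these data alone, how a morpholine ring or a carboxylic acid at the same place would read also remains open.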